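Replacing Fluoro With Benzylamino on a Cytotoxic Core

The source may report more compounds than this note shows. Statements on the series, on what has been measured and on what is new or still open speak of the compounds shown alone.

Going by the values given here, compound 2 `N#Cc1c(NCc2ccccc2)c(Cl)c2nc(N)nc(N)c2c1F` gives 1.4 ug/mL in a functional assay on A-431 cells (Homo sapiens) for cytotoxicity, read by MTT assay (a higher number here means a weaker inhibitor, a lower number a stronger inhibitor), the lower of the two numbers measured so far. Its only companion, compound 1 `N#Cc1c(Nc2ccccc2)c(Cl)c2nc(N)nc(N)c2c1F`, gives 4.8 ug/mL in this assay. Among the compounds with values here, the one measured step between them, a 3.4-fold lower number from compound 1 to compound 2 (0.54 log units; beyond the scatter), concerns a different position and a different kind of exchange from the one considered here. Compound 3 `N#Cc1c(NCc2ccccc2)c(Cl)c2nc(N)nc(N)c2c1NCc1ccccc1` differs from compound 2 in one place: benzylamino in place of fluoro on an aromatic carbon. Within the data shown here, no measured pair shows how this position responds to any change, so the expectation rests only on the scale of change seen on this core, and because a 3.4-fold lower number from compound 1 to compound 2 (0.54 log units; beyond the scatter) was modest, a step of similar or smaller size in either direction is expected. Compound 3 is therefore estimated to give about 2 ug/mL in this assay, within a range from 0.7 ug/mL to 6 ug/mL, which would amount to a 1.4-fold higher number from compound 2 to compound 3 (0.15 log units; within the scatter).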

Compound 3, half-maximal inhibitory concentration: 716 ug/mL
Estimate against measurement, compound 3: 360-fold (2.55 log units) below; measured number outside the range, above it.
By their numbers in this assay, from the lowest: compound 2; then compound 1; then compound 3.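

The aromatic carbon that carries fluoro, ortho to a cyano group and para to a chloro group, proves highly sensitive: replacing fluoro with benzylamino gives a 510-fold higher number from compound 2 to compound 3 (2.71 log units; beyond the scatter) in this assay. This is a far larger step than the only earlier one, a 3.4-fold lower number from compound 1 to compound 2 (0.54 log units; beyond the scatter), so the core does not tolerate every change to the same degree, and this exchange leaves a much weaker inhibitor. No available measurement explains why this carbon responds so strongly.

It remains open whether the loss comes from removing fluoro or from adding benzylamino, as this carbon is shown with only these two groups. An amino group or a methoxy group here would help separate those two possibilities.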